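Methyl in Place of Bromo: an Expected Cytotoxicity Value

This account rests on a few compounds, and the source may have more. Where it says the series, first, only, none or still open, it means among the compounds named here.

Compound 1, `Cc1ccc(-c2csc(NC(=O)COc3ccc(Cl)c(C)c3)n2)cc1`, gives 44900 nM in a functional assay on A549 cells (Homo sapiens) for cytotoxicity, read by MTT assay, with a stated time of 48 h; a higher number here means a weaker inhibitor, a lower number a stronger inhibitor.
Compound 2, `Cc1cc(OCC(=O)Nc2nc(-c3ccc(Br)cc3)cs2)ccc1Cl`, gives 52100 nM in this assay.
Compound 3, `O=C(COc1ccc(F)cc1)Nc1nc(-c2ccc(Br)cc2)cs1`, gives 52100 nM in this assay.

The three measured compounds sit close together. The change methyl in place of bromo on an aromatic carbon gives a 1.2-fold lower number from compound 2 to compound 1 (0.06 log units; within the scatter). The two cores differ as 4-fluorophenyl in place of 4-chloro-3-methylphenyl on an oxygen on a saturated carbon, and that gives no change at the digits printed from compound 2 to compound 3 (within the scatter). Compound 3 and compound 2 are level at the digits printed, and compound 1 is within the scatter of both, so no ordering among the three can be read from these numbers.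

Compound 4, `Cc1ccc(-c2csc(NC(=O)COc3ccc(F)cc3)n2)cc1`, is not yet measured. It differs from compound 3 by methyl in place of bromo on an aromatic carbon. Among the measured compounds shown here, this is the same change as from compound 2 to compound 1, at the same place in the same words, so the earlier step is the only guide. Because a 1.2-fold lower number from compound 2 to compound 1 (0.06 log units; within the scatter) lay within the scatter, compound 4 is expected to show a 1.2-fold lower number from compound 3 to compound 4 (0.07 log units; within the scatter), again within the scatter. Compound 4 is therefore estimated at 44000 nM in this assay, with an expected range from 22000 nM to 90000 nM.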

Compound 4, half-maximal inhibitory concentration: 19300 nM
Compound 4: middle estimate off by 2.3-fold (0.36 log units), on the high side, outside the stated range (below it).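

In this assay, methyl in place of bromo gives a 2.7-fold lower number from compound 3 to compound 4 (0.43 log units; beyond the scatter), and 4-fluorophenyl in place of 4-chloro-3-methylphenyl gives a 2.3-fold lower number from compound 1 to compound 4 (0.37 log units; beyond the scatter). Each of these steps lies beyond the scatter while its earlier counterpart lies within it, yet that contrast does not show that methyl in place of bromo depends on the core: the same change on two cores in this assay, a 1.2-fold lower number (0.06 log units; within the scatter) from compound 2 to compound 1 and a 2.7-fold lower number (0.43 log units; beyond the scatter) from compound 3 to compound 4, 2.3-fold (0.37 log units) apart, within the scatter of two such steps. Among the compounds shown here, the change on the oxygen reads the same way, so the series shows no measured difference between the two cores for either change, but with only two cores it does not establish that either step carries over unchanged to other cores: the same change on two cores in this assay, no change at the digits printed (within the scatter) from compound 2 to compound 3 and a 2.3-fold lower number (0.37 log units; beyond the scatter) from compound 1 to compound 4, 2.3-fold (0.37 log units) apart, within the scatter of two such steps.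

The compounds shown hold only bromo or methyl on the aromatic carbon para to a large group, so what an amine, a carboxylic acid or a longer chain would give there remains open. Also open, going by these compounds, is whether the step from compound 1 to compound 4 would recur with a group such as a nitrile in place of the fluoro.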